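Working notes: the step from compound 3 to compound 4

The compounds below may be only part of what the source reports. "The series", "measured", "known", "first", "only" and "open" are said of these compounds alone.

In a physicochemical assay for solubility (on this read-out lower numbers stand for lower solubility and higher numbers for higher solubility), compound 3 (`O=S(=O)(Nc1nccs1)c1ccc2c(c1)OCC[C@@H]2c1ccc(C(F)(F)F)cc1-c1ccc(F)cc1`) gives 39000 nM, the second highest of three numbers. Compound 2 (`CN1CCN(c2cc(C(F)(F)F)ccc2[C@H]2CCOc3cc(S(=O)(=O)Nc4nccs4)ccc32)CC1`) stands higher at 176000 nM, and compound 1 (`Cc1nc(-c2cc(C(F)(F)F)ccc2[C@H]2CCOc3cc(S(=O)(=O)Nc4cccc(F)n4)ccc32)co1`) stands lower at 13000 nM.

The next structure, compound 4 (`Cc1nc(-c2cc(C(F)(F)F)ccc2[C@H]2CCOc3cc(S(=O)(=O)Nc4nccs4)ccc32)co1`), keeps the rest of compound 3 and changes one group: 2-methyl-1,3-oxazol-4-yl in place of 4-fluorophenyl on an aromatic carbon. In words, 2-methyl-1,3-oxazol-4-yl takes the place of 4-fluorophenyl on an aromatic carbon, meta to a trifluoromethyl group.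

Within the data shown here, only one measured step touches this place: a 4.5-fold lower number from compound 2 to compound 3 (0.65 log units; beyond the scatter). That step was modest, though beyond the scatter. It brought in the group that now leaves and shows nothing direct about the entering one. Compound 1 already carries 2-methyl-1,3-oxazol-4-yl and gives 13000 nM, but it differs from compound 4 elsewhere in the structure, so it is only a loose guide. Among the measured compounds shown here, no measured pair covers this exact exchange, so a small step is expected, with no firm direction. The estimated step is a 1.1-fold lower number from compound 3 to compound 4 (0.05 log units; within the scatter), which is expected to stay within the scatter. For compound 4 the estimate is 35000 nM, with an expected range of 13000 nM to 90000 nM.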

Compound 4, solubility: 61000 nM
For compound 4 the middle estimate is 1.7-fold (0.24 log units) below the measured one; the range from low to high includes it.
By their numbers in this assay, from the lowest: compound 1; then compounds 3 and 4 (each within the scatter of the next); then compound 2.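

In this assay, 2-methyl-1,3-oxazol-4-yl in place of 4-fluorophenyl gives a 1.6-fold higher number from compound 3 to compound 4 (0.19 log units; within the scatter) and so does not separate the two aromatic groups at this position, while a 2.9-fold lower number from compound 2 to compound 4 (0.46 log units; beyond the scatter) joins a 4.5-fold lower number from compound 2 to compound 3 (0.65 log units; beyond the scatter) as a second exchange away from 4-methylpiperazin-1-yl that ends at a lower number, beyond the scatter. The sulfonamide nitrogen also matters in this series: with 2-methyl-1,3-oxazol-4-yl held in place, 1,3-thiazol-2-yl in place of 6-fluoropyridin-2-yl gives a 4.7-fold higher number from compound 1 to compound 4 (0.67 log units; beyond the scatter) and is a modest step, like the two exchanges from compound 2. No available evidence gives a reason for any of these steps.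

On these data alone, it remains open whether a primary amine, a carboxylic acid or a morpholine at this aromatic carbon would give a number close to those of compound 3 and compound 4 or close to that of compound 2. As far as these compounds go, it is also open whether the step at the sulfonamide nitrogen would hold with other groups on the aromatic carbon, as it rests on a single pair of compounds.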